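A few compounds are considered here, and "the series" means these few. Any claim that something is new, unique, unknown or untested is made for them only; others in the source may bear on it.

Measured in an assay on HEK293 cells for positive allosteric modulation of metabotropic glutamate receptor 2 (Rattus norvegicus), read by thallium flux, with a stated time of 2.5 min; on this read-out lower numbers stand for an effect already at smaller amounts and higher numbers for an effect only at larger amounts of compound:
compound 1, `COc1ccc(C(=O)O)cc1OCCCCOc1ccc(C(=O)CC2CCCC2)c(O)c1C`, gives 425 nM
compound 2, `COc1ccc(C(=O)O)cc1OCCCCOc1ccc(C(C)=O)c(O)c1C`, gives 1090 nM
compound 3, `CC(=O)c1ccc(OCCCCOc2ccc(C(=O)O)cc2C)c(C)c1O`, gives 50 nM

Compound 3 has the lowest number of the three, and its steps to both others lie beyond the scatter. Compound 2 and compound 3 share no single counted difference; the difference between their two cores is not broken down here.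

Compound 4, `Cc1cc(C(=O)O)ccc1OCCCCOc1ccc(C(=O)CC2CCCC2)c(O)c1C`, relates to compound 3 as compound 1 relates to compound 2: cyclopentyl in place of hydrogen on a saturated chain carbon bound to a carbonyl carbon on the core of compound 3, and cyclopentyl in place of hydrogen on a saturated chain carbon bound to a carbonyl carbon on the core of compound 2, the same change at the same place. On the core of compound 2 that change gave a 2.6-fold lower number from compound 2 to compound 1 (0.41 log units; beyond the scatter).

In this assay, among the measured compounds shown here, the step from compound 3 to compound 4 is expected to be of similar size, a 2.3-fold lower number from compound 3 to compound 4 (0.36 log units; beyond the scatter), because a 2.6-fold lower number from compound 2 to compound 1 (0.41 log units; beyond the scatter) is the only measured instance of this change and rests on one pair alone. Compound 4 is accordingly estimated at 22 nM, with a likely range from 8 nM to 60 nM.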

Compound 4, half-maximal effective concentration: 608 nM
Compound 4: the middle estimate sits 28-fold (1.44 log units) below what was measured; the whole stated range lies below it.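

In this assay the change of cyclopentyl in place of hydrogen on a saturated chain carbon bound to a carbonyl carbon did not carry from one core to the other, and the two instances run in opposite directions: the same change on two cores in this assay, a 2.6-fold lower number (0.41 log units; beyond the scatter) from compound 2 to compound 1 and a 12-fold higher number (1.08 log units; beyond the scatter) from compound 3 to compound 4, 31-fold (1.49 log units) apart, beyond the scatter of two such steps. On the core of compound 3 the change gives a 12-fold higher number from compound 3 to compound 4 (1.08 log units; beyond the scatter) and, with cyclopentyl present on both, exchanging the other aryl group gives a 1.4-fold higher number from compound 1 to compound 4 (0.16 log units; within the scatter). The outcome of this change therefore depends on the core in these two pairs, but with one pair per core the result gives no reason for the reversal and no rule for other cores.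

As far as these compounds go, whether an ethyl or a phenyl group in place of cyclopentyl would reverse in the same way remains open. So does the effect of a tetrazole in place of the carboxylic acid on either core.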